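Swapping the Aryl Group on the Ring Nitrogen

The compounds below may be only part of what the source reports. "The series", "measured", "known", "first", "only" and "open" are said of these compounds alone.

Measured compounds:
compound 1, `O=C(Nc1ccc(Oc2ccnc3[nH]ccc23)c(F)c1)c1nn(-c2ccc(Br)cc2)ccc1=O`: 68000 nM
compound 2, `O=C(Nc1ccc(Oc2ccnc3[nH]ccc23)c(F)c1)c1nn(-c2ccc(Br)cc2F)ccc1=O`: 56500 nM

Compound 2 and compound 1 share the whole of their structure apart from one aromatic hydrogen replaced by fluorine, and in a functional assay on HepG2 cells (Homo sapiens) for cytotoxicity, read by MTT assay, with a stated time of 72 h (a lower number here means a stronger inhibitor, a higher number a weaker inhibitor), compound 2 gives 56500 nM while compound 1 gives 68000 nM. The step of a 1.2-fold lower number from compound 1 to compound 2 (0.08 log units; within the scatter) is within the scatter, so the two compounds cannot be set apart on these numbers; compound 2 simply has the lower reading of the pair.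

Compound 3 `O=C(Nc1ccc(Oc2ccnc3[nH]ccc23)c(F)c1)c1nn(-c2ccc(Cl)c(C(F)(F)F)c2)ccc1=O` carries a different aryl group: 4-chloro-3-(trifluoromethyl)phenyl in place of 4-bromo-2-fluorophenyl on an aromatic nitrogen. Going by the values given here, only one measured step bears on a change at this position, and that step, a 1.2-fold lower number from compound 1 to compound 2 (0.08 log units; within the scatter), did not leave the scatter. Nothing in the data therefore points to a step in this assay beyond the scatter, in either direction. For compound 3 the expected value in this assay is 50000 nM, estimated to lie between 20000 nM and 150000 nM. The expected step is a 1.1-fold lower number from compound 2 to compound 3 (0.05 log units; within the scatter).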

Compound 3, half-maximal inhibitory concentration: 11900 nM
Estimate against measurement, compound 3: 4.2-fold (0.62 log units) above, outside the stated range (below it).
By their numbers in this assay, from the lowest: compound 3; then compounds 2 and 1 (each within the scatter of the next).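

In this assay, going by these compounds alone, the aryl group on the ring nitrogen proves able to move the number beyond the scatter, which the single fluorine swap did not: 4-chloro-3-(trifluoromethyl)phenyl gives a 4.7-fold lower number from compound 2 to compound 3 (0.68 log units; beyond the scatter) and a 5.7-fold lower number from compound 1 to compound 3 (0.76 log units; beyond the scatter), both modest in size. This change alters more than one feature of the aryl group at once, so the steps cannot be assigned to the chlorine, the trifluoromethyl group or their placement on the ring. No measurement at hand accounts for the lower numbers.

From the compounds shown here alone, it remains open which of these parts carries the step, and whether an amine, a carboxylic acid or a nitrile on this aryl ring would shift the number further. Also open, going by these compounds, is how an alkyl chain in place of the aryl group on the ring nitrogen would read.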